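The compounds below may be only part of what the source reports. "The series", "measured", "known", "first", "only" and "open" are said of these compounds alone.

In a functional assay on DU-145 cells (Homo sapiens) for antiproliferative activity, read by CCK-8 assay, with a stated time of 72 h (on this read-out lower numbers stand for stronger inhibition and higher numbers for weaker inhibition), compound 2 (`Cc1cc(Nc2cc(N3CCN(C)CC3)nc(Nc3cccc([N+](=O)[O-])c3)n2)n[nH]1`) gives 1340 nM and compound 1 (`Cc1cc(Nc2cc(N3CCN(C)CC3)nc(Nc3ccc(Cl)cc3)n2)n[nH]1`) gives 2240 nM on the same read-out. Going by the values given here, these are the only two numbers and they lie within the scatter of each other, so compound 2 holds no separate rank.

Compound 3 (`Cc1cc(Nc2cc(N3CCN(C)CC3)nc(Nc3cccc(Cl)c3)n2)n[nH]1`) is compound 2 with chloro in place of nitro on an aromatic carbon, meta to a large group (chloro in place of nitro on an aromatic carbon), which reads as 3-nitrophenyl to 3-chlorophenyl. The data hold no direct comparison of these two groups at the same place. Among the compounds with values here, the one measured step that bears on the change also alters the position of the group. With only a 1.7-fold lower number from compound 1 to compound 2 (0.22 log units; within the scatter) to go on for 3-nitrophenyl in place of 4-chlorophenyl, no step beyond the scatter is expected in this assay in either direction.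

The estimated change is a 1.3-fold higher number from compound 2 to compound 3 (0.13 log units; within the scatter) and no more than that is expected. For compound 3 the estimated value is 1800 nM with an expected range from 800 nM to 4000 nM on repeat measurement.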

Compound 3, half-maximal inhibitory concentration: 3090 nM
Estimate against measurement, compound 3: 1.7-fold (0.23 log units) below; measured number inside the range.
By their numbers in this assay, from the lowest: compounds 2, 1 and 3 (each within the scatter of the next, the first and the last beyond it).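

In this assay, going by these compounds alone, the first comparison of the two groups at one place gives a 2.3-fold higher number from compound 2 to compound 3 (0.36 log units; beyond the scatter), a modest step on exchanging nitro for chloro on an aromatic carbon of the phenyl ring. Moving the chloro, as 3-chlorophenyl in place of 4-chlorophenyl, gives a 1.4-fold higher number from compound 1 to compound 3 (0.14 log units; within the scatter), so in this pair the place of the chloro does not separate the two compounds, and among the three pairs now available only the exchange of nitro for chloro passes beyond the scatter. No measurement accompanies these numbers that would tie the step to any property of either group.

On these data alone, whether an amine, a methoxy group or a carboxylic acid at this place would stand with nitro, with chloro or apart from both remains open, as a single step between two groups gives no trend across substituents. Also open, as far as these compounds go, is whether the step between 3-nitrophenyl and 3-chlorophenyl keeps its size when a different group is carried elsewhere on the shared core.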